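Nitrophenyl Analogue of a Naphthyloxymethyl Oxadiazole Semicarbazone

This account rests on a few compounds, and the source may have more. Where it says the series, first, only, none or still open, it means among the compounds named here.

In a functional assay on the whole organism (strain Wistar) with Rattus norvegicus as the target, with a stated time of 4 h (a lower number here means that less compound is needed, a higher number that more compound is needed for the effect), compound 1 `C/C(=N/NC(=O)Nc1nnc(COc2ccc3ccccc3c2)o1)c1ccc(N)cc1` gives 300 mg/kg. Compound 2 `COc1cc(/C=N\NC(=O)Nc2nnc(COc3ccc4ccccc4c3)o2)ccc1O` gives 300 mg/kg in this assay, level with compound 1 at the digits shown and within the scatter of it. Compound 3 `O=C(N/N=C\c1ccc([N+](=O)[O-])cc1)Nc1nnc(COc2ccc3ccccc3c2)o1` has not yet been tested. It differs from compound 2 by 4-nitrophenyl in place of 4-hydroxy-3-methoxyphenyl on a carbon with a double bond to nitrogen. Going by the values given here, no step between measured compounds is known, so no direction beyond the scatter is expected; the step from compound 2 is estimated as no change at the digits printed from compound 2 to compound 3 (within the scatter). Compound 3 is therefore expected to give about 300 mg/kg in this assay, with a range from 150 mg/kg to 600 mg/kg.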

Compound 3, minimum effective dose: 300 mg/kg
Compound 3: the middle estimate sits on the measured number at the digits printed; low and high end bracket the measured number.
By their numbers in this assay, from the lowest: compounds 1, 2 and 3 (each within the scatter of the next).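

Replacing 4-hydroxy-3-methoxyphenyl with 4-nitrophenyl on a carbon with a double bond to nitrogen gives no change at the digits printed from compound 2 to compound 3 (within the scatter) in this assay. This first readable step at this position shows that the minimum effective dose holds when the hydrogen-bond donor of the leaving group is gone. Nothing measured here offers an explanation for this result.

From the compounds shown here alone, whether an unsubstituted phenyl, a carboxylic acid or a dimethylamino group at this position would shift the dose remains open. Since both aryl groups sit level, the compounds shown do not reveal whether any change here can move it.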